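A few compounds are considered here, and "the series" means these few. Any claim that something is new, unique, unknown or untested is made for them only; others in the source may bear on it.

Measured in a toxicity assay on NIH3T3 cells (Mus musculus) for cytotoxicity, read by resazurin assay; a higher number here means that more compound is needed for the effect, a lower number that less compound is needed:
Compound 1, `COC(=O)c1ccc(NCc2cncn2Cc2cccc(C)c2)cc1-c1ccccc1`, gives > 10000 nM, a limit of the assay.
Compound 2, `COC(=O)c1ccc(NCc2cncn2Cc2cccc(C#N)c2)cc1-c1ccccc1`, gives > 10000 nM, a limit of the assay.
Compound 3, `COC(=O)c1ccc(NCc2cncn2Cc2ccc(C#N)cc2)cc1-c1ccccc1`, gives > 10000 nM, a limit of the assay.

The three measured compounds share one core and differ only in the benzyl group on the imidazole ring. Compound 2 and compound 3 are built from the same atoms joined differently, (4-cyanophenyl in place of 3-cyanophenyl on a saturated chain carbon bound to an aromatic nitrogen), and the step between them is a step that the two limits leave unreadable from compound 2 to compound 3. Compound 2 and compound 1 differ by methyl in place of cyano on an aromatic carbon, with the step that the two limits leave unreadable from compound 2 to compound 1. Compound 1 and compound 3 are linked by a step that the two limits leave unreadable from compound 1 to compound 3. None of these steps can be sized, since every value stops at the limit of > 10000 nM in this assay, at which 3 of the 3 values shown sit.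

Compound 4, `COC(=O)c1ccc(NCc2cncn2Cc2ccc(C)cc2)cc1-c1ccccc1`, is not yet measured in this assay. It differs from compound 3 by methyl in place of cyano on an aromatic carbon. Among the measured compounds shown here, this is the same kind of change as the one from compound 2 to compound 1, not the same: there the place is "meta to a large group", here it is "para to a large group".

For compound 4 the step that the limit leaves unreadable from compound 3 to compound 4 is expected to be small, an expectation that rests on compound 3 sitting at the limit of > 10000 nM in this assay, at which 3 of the 3 values shown sit, together with the other two measured values. Compound 4 is therefore estimated to reach 20000 nM, most likely again reported as a limit, with a range from 8000 nM to 100000 nM.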

Compound 4, half-maximal effective concentration: 50000 nM
Compound 4: middle estimate off by 2.5-fold (0.40 log units), on the low side; the range from low to high includes it.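

Among the compounds shown here, no step to compound 4 from compound 1, compound 2 or compound 3 can be read in this assay, because the values of those three compounds are limits of the assay and not numbers: the limit of > 10000 nM in this assay, at which 3 of the 4 values shown sit.

The compounds shown leave open whether exchanging cyano for methyl, or changing the position of either group on the benzyl group, alters the concentration needed in this assay at all.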